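Tert-butyl in place of ethoxycarbonyl: compound 3 to compound 4

This account rests on a few compounds, and the source may have more. Where it says the series, first, only, none or still open, it means among the compounds named here.

The three measured compounds differ in one group on the shared core. In a functional assay on MCF7 cells (Homo sapiens) for inhibition, read by CCK-8 assay, with a stated time of 48 h (a lower number here means a stronger inhibitor, a higher number a weaker inhibitor), compound 1 `COc1cc(-c2ccnc3cc(-c4ccc(C(F)(F)F)cc4)nn23)cc(OC)c1OC` gives 2440 nM, and compound 2 `COc1cc(-c2ccnc3cc(-c4ccc(N(C)C)cc4)nn23)cc(OC)c1OC` gives 44 nM. Compound 3 `CCOC(=O)c1ccc(-c2cc3nccc(-c4cc(OC)c(OC)c(OC)c4)n3n2)cc1` reports > 10000 nM, which is a limit of the assay and not a number.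

Compound 4 `COc1cc(-c2ccnc3cc(-c4ccc(C(C)(C)C)cc4)nn23)cc(OC)c1OC` arises from compound 3 through one change: tert-butyl in place of ethoxycarbonyl on an aromatic carbon. Tert-butyl replaces ethoxycarbonyl on an aromatic carbon of a six-membered aromatic ring of carbon only, para to a large group.

Three measured steps at this place bear on the change. Within the data shown here, the one step between two numbers is large: a 55-fold lower number from compound 1 to compound 2 (1.74 log units; beyond the scatter). The two steps into compound 3 both raise the number: an at least 4.0-fold higher number from compound 1 to compound 3 (0.61 log units; beyond the scatter) and an at least 220-fold higher number from compound 2 to compound 3 (2.35 log units; beyond the scatter). Leaving ethoxycarbonyl is therefore expected to lower the number in this assay. Among the measured compounds shown here, its size stays loose, as compound 3 has no exact number and no measured compound carries tert-butyl. The expected change is an at least 6.6-fold lower number from compound 3 to compound 4 (0.82 log units; beyond the scatter), at least modest in size. For compound 4 the estimate is 1500 nM, with an expected range from 300 nM to 7000 nM.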

Compound 4, half-maximal inhibitory concentration: > 10000 nM
Compound 4 ended at the assay's limit; the forecaster's own chance of this, stated with the estimate: 10%; middle value at least 6.6-fold (0.82 log units) from the limit.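

In this assay, tert-butyl in place of dimethylamino gives an at least 220-fold higher number from compound 2 to compound 4 (2.35 log units; beyond the scatter), and tert-butyl in place of trifluoromethyl gives an at least 4.0-fold higher number from compound 1 to compound 4 (0.61 log units; beyond the scatter). The loss seen with ethoxycarbonyl is therefore not confined to that group: tert-butyl, which carries no hydrogen-bond acceptors, also leaves compound 4 at a limit of the assay, so the hydrogen-bond acceptors of ethoxycarbonyl cannot be what sets compound 3 apart from compound 1 and compound 2. The step between compound 3 and compound 4 cannot be read, and the order of the two groups stays unknown, because both compounds stand at the same limit: the limit of > 10000 nM in this assay, at which 2 of the 4 values shown sit.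

From the compounds shown here alone, of the four groups at this place, only dimethylamino gives a value near the low end, and it remains open whether that depends on the nitrogen itself or on its two methyl groups, which a primary amine, a methylamino group or a pyrrolidine at the same place would help to separate. A methoxy group or a carboxylic acid there would show whether the steep fall from compound 2 is specific to the groups seen so far.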